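The source may report more compounds than this note shows. Statements on the series, on what has been measured and on what is new or still open speak of the compounds shown alone.

- Compound 1 `Cc1ccn2c(CN3CCCCC3)c(-c3ccccc3)nc2n1`: 1710 nM
- Compound 2 `Oc1ccc(-c2nc3ncccn3c2CN2CCCCC2)cc1`: 4030 nM
- Compound 3 `Cc1ccn2c(CN3CCCC3)c(-c3ccc(O)cc3)nc2n1`: 4760 nM

In a functional assay on HeLa cells (Homo sapiens) for inhibition, read by sulforhodamine B assay, with a stated time of 48 h (on this read-out lower numbers stand for stronger inhibition of growth and higher numbers for weaker inhibition of growth), compound 2 gives 4030 nM. Going by the values given here, that number lies within the scatter of the one for compound 3, while compound 1 reads lower, beyond the scatter. Compound 4 `c1ccc(-c2nc3ncccn3c2CN2CCCCC2)cc1` arises from compound 2 through a single change: hydrogen in place of hydroxy on an aromatic carbon. In words, hydrogen stands in place of hydroxy on an aromatic carbon, so 4-hydroxyphenyl becomes phenyl.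

Among the compounds with values here, no two measured compounds differ in this one place alone, so the data hold no direct precedent for the step. The nearest hint is compound 1, which also carries phenyl and gives 1710 nM, although it differs from compound 2 in a second place as well. On this limited evidence, a modest drop in the number is expected in this assay, close to the edge of the scatter. The estimated change is a 1.8-fold lower number from compound 2 to compound 4 (0.24 log units; within the scatter). For compound 4 the estimated value is 2300 nM, with an expected range from 1000 nM to 5000 nM.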

Compound 4, concentration for 50% growth inhibition: 2280 nM
Compound 4: middle estimate off by 1.0-fold (0.00 log units), on the high side, within the range that was stated.
By their numbers in this assay, from the lowest: compounds 1, 4, 2 and 3 (each within the scatter of the next, the first and the last beyond it).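

In this assay, going by these compounds alone, the first direct comparison at this position is now available: swapping hydroxy for hydrogen, 4-hydroxyphenyl to phenyl, gives a 1.8-fold lower number from compound 2 to compound 4 (0.25 log units; within the scatter), so this hydroxy is not needed for growth inhibition in this range. The second comparison concerns a different place, an aromatic carbon of the core, where hydrogen replaces methyl and gives a 1.3-fold higher number from compound 1 to compound 4 (0.12 log units; within the scatter), so neither single change moves the number past ordinary assay variation. Nothing available explains why these two changes have so little effect.

On these data alone, only hydroxy and hydrogen can be compared at this position, so it remains open whether methoxy, fluorine, an amine or a carboxylic acid would shift the number beyond the scatter. As far as these compounds go, the effect of the saturated amine ring on its own also remains open, since compound 3 differs from each of the other compounds in more than one place.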